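Halogenated aryl ketone in a naphthyl oxyacetamide series

The compounds below may be only part of what the source reports. "The series", "measured", "known", "first", "only" and "open" are said of these compounds alone.

Measured so far in an ADME assay on C8166 cells (Homo sapiens) for cytotoxicity, read by colorimetric assay and MTT assay; on this read-out higher numbers stand for lower toxicity in this test and lower numbers for higher toxicity in this test:
Compound 1, `Cc1cc(S(N)(=O)=O)ccc1NC(=O)COc1ccc2ccccc2c1C(=O)c1ccccc1`, gives 33800 nM.
Compound 2, `Cc1ccc(C(=O)c2c(OCC(=O)Nc3ccc(S(N)(=O)=O)cc3C)ccc3ccccc23)c(C)c1`, gives 25500 nM.
Compound 3, `Cc1ccc(C(=O)c2c(OCC(=O)Nc3ccc(S(N)(=O)=O)cc3C)ccc3ccccc23)cc1C`, gives 33000 nM.

Compound 1 carries the highest of the three numbers, yet its steps to the other two lie within the scatter: a 1.3-fold lower number from compound 1 to compound 2 (0.12 log units; within the scatter) and a 1.0-fold lower number from compound 1 to compound 3 (0.01 log units; within the scatter). The remaining measured step is also within it: a 1.3-fold higher number from compound 2 to compound 3 (0.11 log units; within the scatter). Compound 4, `Cc1cc(S(N)(=O)=O)ccc1NC(=O)COc1ccc2ccccc2c1C(=O)c1cc(Cl)cc(Br)c1`, has not yet been measured. It differs from compound 1 in one place: 3-bromo-5-chlorophenyl in place of phenyl on a carbonyl carbon. The two steps from compound 1 bear directly on this change, since each likewise exchanges the phenyl on the carbonyl carbon for a substituted phenyl, and neither moved the number beyond the scatter. The new group carries a bromine and a chlorine rather than methyl groups, so those steps are only a loose guide. Compound 4 is therefore expected to show a step of a 1.2-fold lower number from compound 1 to compound 4 (0.08 log units; within the scatter), not beyond the scatter. The estimate for compound 4 in this assay is 28000 nM, within a range from 12000 nM to 60000 nM.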

Compound 4, half-maximal cytotoxic concentration: 36600 nM
Compound 4: middle estimate off by 1.3-fold (0.12 log units), on the low side, and the stated range covers the measured number.
By their numbers in this assay, from the lowest: compounds 2, 3, 1 and 4 (each within the scatter of the next).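

In this assay, replacing phenyl on the carbonyl carbon with 3-bromo-5-chlorophenyl gives a 1.1-fold higher number from compound 1 to compound 4 (0.03 log units; within the scatter), so a ring bearing bromine and chlorine joins the two dimethylphenyl rings in leaving the number within the scatter. Compared directly with those rings, the new group gives a 1.1-fold higher number from compound 3 to compound 4 (0.04 log units; within the scatter) and a 1.4-fold higher number from compound 2 to compound 4 (0.16 log units; within the scatter), so all four groups shown at this position lie within the scatter of one another, whether the ring carries methyl groups, halogens or nothing. Nothing available explains why these exchanges leave the number within the scatter.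

The compounds shown leave open whether an amine or a carboxylic acid on this ring would stay within the scatter. They also leave open whether a longer chain in place of the ring, or a change elsewhere on the shared core, would move the number beyond it.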